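Amine nitrogen substituent change in a chemokine receptor antagonist series

The source may hold more compounds than are shown below. What is called first, only, known or untested is meant among the compounds shown, and "the series" means these compounds.

Measured compounds:
Compound 1, `CCCN(C[C@H]1Cc2c(cccc2N2CCNCC2)CN1)[C@H]1CCCc2cccnc21`, gives 32.2 nM.
Compound 2, `CN1CCN(c2cccc3c2C[C@H](CN(C)[C@H]2CCCc4cccnc42)N(C)C3)CC1`, gives 171 nM.
Compound 3, `CN(C[C@H]1Cc2c(cccc2N2CCN3CCC[C@@H]3C2)CN1)[C@H]1CCCc2cccnc21`, gives 3.59 nM.

All three values come from a functional assay on CCRF-CEM cells for antagonist activity at C-X-C chemokine receptor type 4 (Homo sapiens), read by calcium flux, with stated times of 25 min and 90 s; on this read-out higher numbers stand for weaker inhibition and lower numbers for stronger inhibition. Among them compound 1 stands second highest: compound 2 gives a higher number than compound 1, a gap beyond the usual scatter, while compound 3 gives a lower number than compound 1, also beyond the scatter. Compound 2 and compound 3 differ from compound 1 in more than one place, so no single change is isolated between any pair of measured compounds.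

Compound 4, `CC(C)N(C[C@H]1Cc2c(cccc2N2CCNCC2)CN1)[C@H]1CCCc2cccnc21`, has not yet been measured in this assay. Compared with compound 1 the change is isopropyl in place of propyl on an amine nitrogen. The two compounds share the same atoms, joined differently. Nothing in the measured set shows how this kind of change behaves, so the expectation rests on the small size of the change alone. The step from compound 1 to compound 4 is expected to be a 1.1-fold higher number from compound 1 to compound 4 (0.04 log units; within the scatter), within the scatter, in no particular direction. For compound 4 the expected value is 35 nM, with a range from 12 nM to 100 nM.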

Compound 4, half-maximal inhibitory concentration: 364 nM
Compound 4: the middle estimate sits 10-fold (1.02 log units) below what was measured; measured number outside the range, above it.
By their numbers in this assay, from the lowest: compound 3; then compound 1; then compound 2; then compound 4.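

In this assay, moving from propyl to isopropyl on the amine nitrogen gives an 11-fold higher number from compound 1 to compound 4 (1.05 log units; beyond the scatter), the first single change isolated in this series. The size of this step shows that the position is sensitive to how the same three carbons are joined, even with the heavy-atom count and the hydrogen-bond donor and acceptor counts unchanged. No available evidence accounts for this loss of inhibition.

From the compounds shown here alone, this reading rests on a single pair, so it remains open whether the same step would appear with a different substituent elsewhere on the shared core. Going by these compounds, it also remains open how ethyl, isobutyl or cyclopropyl on this amine nitrogen would compare with propyl and isopropyl, and so whether the weaker inhibition is specific to isopropyl.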